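Series notes: cytotoxicity, step from compound 3 to compound 4

The source may report more compounds than this note shows. Statements on the series, on what has been measured and on what is new or still open speak of the compounds shown alone.

Measured compounds:
- compound 1 `Cc1nc(-c2cccnc2)sc1-c1nnc(-c2ccncc2)o1`; in an ADME assay on THP-1 cells (Homo sapiens) for cytotoxicity, read by MTT assay (on this read-out lower numbers stand for higher toxicity in this test and higher numbers for lower toxicity in this test), compound 1 gives > 100 ug/mL, which is a limit of the test and not a number.
- compound 2 `Cc1nc(-c2cccnc2)sc1-c1nnc(-c2cccnc2)o1`; in this assay compound 2 gives > 100 ug/mL, again a limit.
- compound 3 `Cc1nc(-c2cccnc2)sc1-c1nnc(-c2ccccc2)o1`; in this assay compound 3 gives > 100 ug/mL, again a limit.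

Compound 3 therefore stands at the same limit as the other two members, and nothing in the numbers sets it apart from them: the limit of > 100 ug/mL in this assay, at which 3 of the 3 values shown sit. The steps among the measured compounds carry no size for the same reason: a step that the two limits leave unreadable from compound 1 to compound 2, a step that the two limits leave unreadable from compound 1 to compound 3 and a step that the two limits leave unreadable from compound 2 to compound 3 are all unreadable between two limits.

Compound 4 `Cc1ccccc1-c1nnc(-c2sc(-c3cccnc3)nc2C)o1` differs from compound 3 by methyl in place of hydrogen on an aromatic carbon. Going by the values given here, none of the measured steps concerns a methyl in place of hydrogen, and the three steps that exist give no size at all, so no direction can be read from them. The expectation for this assay is that compound 4 again sits at the limit, with no step beyond the scatter, that is a step that the limit leaves unreadable from compound 3 to compound 4 as the expected step. Compound 4 is thus estimated at 150 ug/mL, within 60 ug/mL to 400 ug/mL, most likely reported as a limit only.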

Compound 4, half-maximal cytotoxic concentration: > 100 ug/mL
Compound 4 ended at the assay's limit; the forecaster's own chance of this, stated with the estimate: 85%; the middle value does not contradict the limit.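

In this assay no step can be read among compound 1, compound 2, compound 3 and compound 4, since all four stand at one limit, which is not a number: the limit of > 100 ug/mL in this assay, at which 4 of the 4 values shown sit.

The compounds shown leave open where any of the four would reach half-maximal cytotoxicity, and whether methyl in place of hydrogen changes this read-out at all.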